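From pyridin-4-yl to ethoxy: a working estimate

This account rests on a few compounds, and the source may have more. Where it says the series, first, only, none or still open, it means among the compounds named here.

In a functional assay on A549 cells (Homo sapiens) for inhibition, read by MTT assay, with a stated time of 72 h (on this read-out lower numbers stand for stronger inhibition and higher numbers for weaker inhibition), compound 1 `Cc1ccc(-c2cc(C(=O)N3CCC4(CC3)CC(=O)c3nn(C(C)(C)C)cc3O4)c3ccccc3n2)cc1` gives 5300 nM and compound 2 `CC(C)(C)n1cc2c(n1)C(=O)CC1(CCN(C(=O)c3cc(-c4ccncc4)nc4ccccc34)CC1)O2` gives 550 nM on the same read-out. Among the compounds with values here, compound 2 therefore holds the lower of the two numbers, and compound 1 is its only neighbour.

Within the data shown here, compound 3 `CCOc1cc(C(=O)N2CCC3(CC2)CC(=O)c2nn(C(C)(C)C)cc2O3)c2ccccc2n1` has no measurement yet. Its change from compound 2 is ethoxy in place of pyridin-4-yl on an aromatic carbon in words, ethoxy in place of pyridin-4-yl on an aromatic carbon next to the ring nitrogen.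

Among the measured compounds shown here, the only measured step bearing on this is a 9.6-fold lower number from compound 1 to compound 2 (0.98 log units; beyond the scatter) with pyridin-4-yl in place of 4-methylphenyl on that same carbon. That single step shows that the number can move beyond the scatter with the group at this carbon. For the measured compounds named here, no measured compound lacks a ring there, so the direction rests on little. Since compound 2 sits at 550 nM as the lower number, a move upward is the more likely outcome.

The expected change is a 3.6-fold higher number from compound 2 to compound 3 (0.56 log units; beyond the scatter) in this assay as a moderate estimated loss. The estimated value for compound 3 is 2000 nM (range 500 nM to 8000 nM).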

Compound 3, half-maximal inhibitory concentration: > 10000 nM
Compound 3: a limit, no number; the forecaster's own chance of this, stated with the estimate: 5%; at least 5.0-fold (0.69 log units) between middle value and limit.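

Compound 3 gives no number in this assay, only a limit: the limit of > 10000 nM in this assay, at which 1 of the 3 values shown sits.

Compounds 1 and 2 both carry a six-membered aromatic ring on this aromatic carbon next to the ring nitrogen, whereas the ethoxy of compound 3 has no ring, and the reading is an at least 18-fold higher number from compound 2 to compound 3 (1.25 log units; beyond the scatter), so a group without a ring here can take the series from a measurable value to the limit of the assay. Against the other ring-bearing compound the reading is an at least 1.8-fold higher number from compound 1 to compound 3 (0.27 log units; that floor lies within the scatter), so this comparison gives only a floor and does not set compound 3 apart from compound 1.

With a single ringless group shown, it stays open whether the loss follows from removing the ring or is particular to ethoxy, and the limit leaves the full size of the step unknown. A dimethylamino group or a longer chain such as butoxy on the same carbon would test the first question, while pyridin-3-yl would show how far the reading depends on where the nitrogen sits in a ring at this carbon.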